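A few compounds are considered here, and "the series" means these few. Any claim that something is new, unique, unknown or untested is made for them only; others in the source may bear on it.

Measured compounds:
- compound 1 `CCc1cccc(-c2nn3c(c2-c2ccnc(Cl)c2)C(C)C(C)(C)C3)n1` gives 82000 nM in a functional assay on K562 cells (Homo sapiens) for cytotoxicity, with a stated time of 72 h; a lower number here means a stronger inhibitor, a higher number a weaker inhibitor.
- compound 2 `Cc1cc(-c2c(-c3cccc(C)n3)nn3c2C(C)C(C)(C)C3)ccn1` reaches only a limit in this assay, > 100000 nM, and this is a limit of the measurement, not a number.

Going by the values given here, compound 1 stands as the one measured compound with a numerical value in this assay; the other measured compound sits at the limit (the limit of > 100000 nM in this assay, at which 1 of the 2 values shown sits). Its potency is weak.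

The step to compound 3 `CCc1cccc(-c2nn3c(c2-c2ccncc2)C(C)C(C)(C)C3)n1` changes one place: hydrogen in place of chloro on an aromatic carbon. Among the compounds with values here, no step between two measured compounds of this kind is available for comparison, so the expectation rests on compound 1 alone. Because compound 1 gives 82000 nM, compound 3 is expected to stay in the weak range, with a step from compound 1 to compound 3 of a 1.2-fold higher number from compound 1 to compound 3 (0.09 log units; within the scatter), near or just beyond the scatter toward weaker inhibition. Compound 3 is estimated at 100000 nM in this assay, within a range of 35000 nM to 300000 nM, with a fair chance of a limit rather than a number.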

Compound 3, half-maximal inhibitory concentration: > 100000 nM
Compound 3: only a limit was reported; the forecaster's own chance of this, stated with the estimate: 40%; the middle value sits exactly at the limit.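

Replacing the chloro of the 2-chloropyridin-4-yl group with hydrogen, to give pyridin-4-yl, yields in this assay an at least 1.2-fold higher number from compound 1 to compound 3 (0.08 log units; that floor lies within the scatter). Going by these compounds alone, this is the first direct read on this place next to the ring nitrogen, but compound 3 has only a limit of the assay and not a number, so the step gives a floor and its true size stays unknown. The chloro therefore cannot be said to matter or not to matter, and the floor gives no sign of a gain from its removal, with most of the series shown now at the limit: the limit of > 100000 nM in this assay, at which 2 of the 3 values shown sit.

From the compounds shown here alone, whether an amine, a methoxy group or a fluoro at this same place would give a number well below the limit remains open. Also open, going by these compounds, is whether any change at this place can reach potency clear of the weak range seen for compound 1.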